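Azide-to-Vinyl Change on a Cytotoxicity Read-out

The compounds below may be only part of what the source reports. "The series", "measured", "known", "first", "only" and "open" are said of these compounds alone.

Measured so far:
compound 1, `CCCCCCCCCO[C@@H]1[C@@H](N)[C@@H](OC[C@H](O)CN=[N+]=[N-])O[C@H](CN)[C@H]1OCCCCCCCCC`, 62.2%
compound 2, `C=CCO[C@H]1O[C@H](CN)[C@@H](O)[C@H](O)[C@H]1N`, 82.2%
compound 3, `NC[C@H]1O[C@H](O[C@H]2[C@H](O)[C@@H](O)[C@H](N)C[C@@H]2N)[C@H](N)[C@@H](OCCCc2ccc3ccccc3c2)[C@@H]1OCCCc1ccc2ccccc2c1`, 87.7%

In a toxicity assay on the whole organism (J774 cells) for cytotoxicity, with Mus musculus as the target, read by MTT assay, with a stated time of 24 h, tested at 10 uM (on this read-out lower numbers stand for a stronger effect and higher numbers for a weaker effect at the one concentration tested), compound 1 gives the lowest of the three numbers; compound 2 lies higher by a margin beyond the scatter, and compound 3 lies higher still, also beyond the scatter. Compound 4, `C=CCO[C@H]1O[C@H](CN)[C@@H](OCCCCCCCCC)[C@H](OCCCCCCCCC)[C@H]1N`, has not yet been measured. It differs from compound 1 by vinyl in place of 2-azido-1-hydroxyethyl on a saturated chain carbon bound to an oxygen on a saturated carbon, the rest of the structure being kept. Within the data shown here, no pair of measured compounds shows this change on its own, so there is no measured step to lean on. A step from compound 1 to compound 4 in this assay is expected to be small, if anything toward a lower number, and likely within the scatter: a number 4.2 percentage points lower from compound 1 to compound 4 (within the scatter). Compound 4 is therefore estimated at 58%, in the range 38% to 78%.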

Compound 4, a percentage reported as activity, at one concentration (the size of the read-out at that concentration, not a potency): 91.4%
For compound 4 the middle estimate is 33.4 percentage points below the measured one, and the stated range ends below it.
By their numbers in this assay, from the lowest: compound 1; then compounds 2, 3 and 4 (each within the scatter of the next).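

In this assay, vinyl in place of 2-azido-1-hydroxyethyl on a saturated chain carbon bound to an oxygen on a saturated carbon gives a number 29.2 percentage points higher from compound 1 to compound 4 (beyond the scatter). This shows that the read-out responds to a change at this place, and that this change moves it toward the weaker effect. Nothing available bears on the reason for this step.

The compounds shown change the azido and hydroxy parts together, so which of them matters stays open. From the compounds shown here alone, how a carboxylic acid or a plain ethyl would read at this place also stays open.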